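The source may report more compounds than this note shows. Statements on the series, on what has been measured and on what is new or still open speak of the compounds shown alone.

Among the compounds with values here, only two compounds have been tested so far, and only one of them gave a true number. Within the data shown here, in a functional assay on NCI-H460 cells (Homo sapiens) for inhibition, read by sulforhodamine B assay, with a stated time of 72 h (a higher number here means a weaker inhibitor, a lower number a stronger inhibitor), compound 2 `CCNC(=O)c1nnn(-c2cc(C(C)C)c(O)cc2O)c1-c1ccc(CN2CCNCC2)cc1` gives 250 nM as its half-maximal inhibitory concentration, the only actual number available. Compound 1 `CC(C)c1cc(-n2cc(-c3ccc(CN4CCN(c5ccccc5)CC4)cc3)nn2)c(O)cc1O` reads > 1000 nM in this assay and this reading is a limit of the assay, not a number.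

Compound 3 `CCNC(=O)c1nnn(-c2cc(C(C)C)c(O)cc2O)c1-c1ccc(CNCCCN(CC)CC)cc1` shares the core of compound 2 but has (3-(diethylamino)propyl)amino in place of piperazin-1-yl on a saturated chain carbon bound to an aromatic carbon and the group that enters has no ring. Among the measured compounds shown here, no two measured compounds differ in one place alone, so the effect of this swap has not been seen directly. The expectation is therefore a small change with no firm direction, one that stays within the usual scatter of repeated measurements. The estimate takes compound 2 at 250 nM as its only anchor. The expected step of a 1.1-fold lower number from compound 2 to compound 3 (0.06 log units; within the scatter) is accordingly minor. Compound 3 is expected at 220 nM with an estimated range from 80 nM to 600 nM in this forecast.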

Compound 3, half-maximal inhibitory concentration: 412 nM
For compound 3 the middle estimate is 1.9-fold (0.27 log units) below the measured one; the measured number falls inside the stated range.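

In this assay, within the data shown here, putting (3-(diethylamino)propyl)amino in place of piperazin-1-yl on a saturated chain carbon bound to an aromatic carbon gives a 1.6-fold higher number from compound 2 to compound 3 (0.22 log units; within the scatter), the only step here between measured compounds that differ in one place. At this place, then, the ring can give way to an open chain, and the group can go from 6 heavy atoms to 9 with no difference that stands clear of the usual scatter of repeated measurements, while the counts of hydrogen-bond donors and acceptors stay the same. Compound 1 carries a limit and not a number, and it differs from the others in more than one place, so no step to it can be read: the limit of > 1000 nM in this assay, at which 1 of the 3 values shown sits.

One swap of this kind cannot show which part of either group matters, whether the second nitrogen, the ring or the diethylamino end. Open too, on these data alone, is what a morpholin-4-yl ring, a plain dimethylamino group or a carboxylic acid would do on the same carbon, and whether a longer chain than the propyl link would give a step beyond the scatter.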